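This account rests on a few compounds, and the source may have more. Where it says the series, first, only, none or still open, it means among the compounds named here.

Working notes on the series. Compound 3 `C=CC[C@H]1C[C@]2([C@@H](C)Cc3cc(N)c(OC)cc3F)OCOC2=CC1=O` gives 29 nM in a functional assay on M14 cells (Homo sapiens) for antiproliferative activity, with a stated time of 72 h (a higher number here means a weaker inhibitor, a lower number a stronger inhibitor), the lowest of the three numbers recorded so far. Compound 1 `C=CC[C@H]1C[C@]2([C@@H](C)Cc3ccc(OC)c(NC(C)=O)c3)OCOC2=CC1=O` gives 85 nM in this assay, and compound 2 `C=CC[C@H]1C[C@]2([C@@H](C)Cc3cc(C)c(OC)cc3F)OCOC2=CC1=O` gives 230 nM. Among the compounds with values here, the only single-point step among the measured compounds is a 7.9-fold lower number from compound 2 to compound 3 (0.90 log units; beyond the scatter), a modest gain.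

Compound 4 `C=CC[C@H]1C[C@]2([C@@H](C)Cc3cc(NC(C)=O)c(OC)cc3F)OCOC2=CC1=O` is the next entry for this assay. It differs from compound 3 by acetyl in place of hydrogen on a nitrogen on an aromatic ring. Within the data shown here, no measured step bears directly on this exchange: the one recorded step, a 7.9-fold lower number from compound 2 to compound 3 (0.90 log units; beyond the scatter), concerns a different swap and does not involve the acetyl group. The closest reference is compound 1, which also carries an acetamido group but on a ring without fluorine and with a different substitution pattern; compound 1 gives 85 nM, whereas compound 3 gives 29 nM. Among the measured compounds shown here, that pair differs in more than one place, so it yields no clean step. On this basis a small loss is expected rather than a gain. Compound 4 is expected to give 65 nM, with a plausible range of 20 nM to 220 nM. This amounts to an expected step of a 2.2-fold higher number from compound 3 to compound 4 (0.35 log units; beyond the scatter), close to the edge of the usual scatter.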

Compound 4, half-maximal inhibitory concentration: 52 nM
Compound 4: the middle estimate sits 1.3-fold (0.10 log units) above what was measured, within the range that was stated.
By their numbers in this assay, from the lowest: compounds 3, 4 and 1 (each within the scatter of the next, the first and the last beyond it); then compound 2.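

In this assay the amino to acetamido exchange on this ring is tolerated, with a 1.8-fold higher number from compound 3 to compound 4 (0.25 log units; within the scatter) lying within the scatter, so a free amino group is not needed here for a number in this range. The advantage over methyl at this place also holds for the acylated nitrogen: a 4.4-fold lower number from compound 2 to compound 4 (0.65 log units; beyond the scatter) stands beyond the scatter and runs the same way as a 7.9-fold lower number from compound 2 to compound 3 (0.90 log units; beyond the scatter) for the free amino group, so both nitrogen groups go with lower numbers than methyl in this small set. The fluoro exchange on the acetamido series adds no separable effect, since a 1.6-fold lower number from compound 1 to compound 4 (0.21 log units; within the scatter) also lies within the scatter.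

From the compounds shown here alone, it remains open whether a longer acyl chain such as butanoyl, a benzoyl group, a methanesulfonamide or a simple dimethylamino group at this nitrogen would keep numbers in this range, and whether a hydroxyl group could take the place of the amino group. No measurement at hand gives a reason for any of these steps.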